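The source may report more compounds than this note shows. Statements on the series, on what has been measured and on what is new or still open speak of the compounds shown alone.

Measured compounds and their values:

Compound 1, `CCCSc1nc(N/N=C/c2cccs2)c2nnn(Cc3ccccc3)c2n1`, in a functional assay on MGC-803 cells (Homo sapiens) for antiproliferative activity, read by MTT assay, with a stated time of 72 h; on this read-out higher numbers stand for weaker inhibition and lower numbers for stronger inhibition: > 64000 nM, which is a limit of the assay and not a number.
Compound 2, `CCCSc1nc(N/N=C/c2ccc(N(C)C)cc2)c2nnn(Cc3ccccc3)c2n1`, in this assay: 13100 nM.
Compound 3, `CCCSc1nc(N/N=C/c2ccccc2F)c2nnn(Cc3ccccc3)c2n1`, in this assay: > 64000 nM, again a limit of the assay rather than a number.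

Compound 3 therefore stands at the limit in this assay, and it shares that position with compound 1 (the limit of > 64000 nM in this assay, at which 2 of the 3 values shown sit), so that compound 2 alone supplies a readable number. Compound 4, `CCCSc1nc(N/N=C/c2ccc3ccccc3c2)c2nnn(Cc3ccccc3)c2n1`, differs from compound 3 in one place: naphthalen-2-yl in place of 2-fluorophenyl on a carbon with a double bond to nitrogen. Among the compounds with values here, no measured step introduces naphthalen-2-yl, so the bearing of the known steps is indirect. The step that the two limits leave unreadable from compound 1 to compound 3 cannot be read between two limits, while an at least 4.8-fold lower number from compound 1 to compound 2 (0.68 log units; beyond the scatter) and an at least 4.8-fold higher number from compound 2 to compound 3 (0.68 log units; beyond the scatter) show that only 4-(dimethylamino)phenyl lifted a compound off the limit. Naphthalen-2-yl carries neither a hydrogen-bond donor nor an acceptor, like the groups it joins and replaces. Compound 4 is therefore expected to remain weak, with an estimate of 45000 nM and a range from 12000 nM to 150000 nM. The expected step of an at least 1.4-fold lower number from compound 3 to compound 4 (0.15 log units; that floor lies within the scatter) is accordingly small and uncertain, and a further limit is thought quite likely.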

Compound 4, half-maximal inhibitory concentration: > 64000 nM
Compound 4: only a limit was reported (the forecaster's own chance of this, stated with the estimate: 55%); middle value at least 1.4-fold (0.15 log units) from the limit.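

Compound 4 is a limit of the assay, not a number, and it joins the compounds held there in this assay: the limit of > 64000 nM in this assay, at which 3 of the 4 values shown sit.

Naphthalen-2-yl in place of 4-(dimethylamino)phenyl gives an at least 4.8-fold higher number from compound 2 to compound 4 (0.68 log units; beyond the scatter), so a second six-membered aromatic ring of carbon only did not lift the compound off the limit. Among the four groups shown on the carbon with a double bond to nitrogen, only 4-(dimethylamino)phenyl gives a readable number, while the steps to compound 4 from compound 1 and compound 3 join two limits and cannot be read.

The compounds shown leave open whether a 4-aminophenyl or 4-methoxyphenyl group would also give a readable number. They also leave open how far a longer chain in place of the propyl group would shift these values.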